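Phenyl in Place of an Amide-Bearing Chain at the Thioether Carbon

The source may hold more compounds than are shown below. What is called first, only, known or untested is meant among the compounds shown, and "the series" means these compounds.

Two compounds anchor this comparison. Compound 1 `CCC(CSC(CCc1ccccc1C#N)c1cccc(CCc2ccc3ccc(Cl)cc3n2)c1)C(=O)O` gives 1 nM in an assay on membranes from lung for binding affinity to cysteinyl leukotriene receptor 1 (Cavia porcellus); a lower number here means a stronger inhibitor, a higher number a weaker inhibitor. Going by the values given here, compound 2 `CC(CCC(SCCC(=O)O)c1cccc(OCc2ccc3ccc(Cl)cc3n2)c1)CC(=O)N(C)C` gives 8.6 nM in this assay; of the two numbers known, compound 2 stands at the higher one, and its gap to compound 1 lies beyond the scatter. Compound 3 `O=C(O)CCSC(CCc1ccccc1)c1cccc(OCc2ccc3ccc(Cl)cc3n2)c1` has not yet been measured. It differs from compound 2 in one place: phenyl in place of 1-((dimethylcarbamoyl)methyl)ethyl on a saturated chain carbon, three bonds along the chain from an aromatic carbon and a sulfur. Among the compounds with values here, no step between measured compounds isolates this change, so its size can only be judged from what the two known values show. Compound 1, which gives 1 nM, carries the nearer counterpart of the entering phenethyl arrangement, while the rest of compound 3 follows compound 2. On that basis the step is expected to be a modest fall in the number, a 2.2-fold lower number from compound 2 to compound 3 (0.33 log units; beyond the scatter), rather than a rise. The estimate for compound 3 in this assay is 4 nM, with a range from 1.2 nM to 14 nM.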

Compound 3, half-maximal inhibitory concentration: 6.5 nM
Compound 3: the middle estimate sits 1.6-fold (0.21 log units) below what was measured; the measured number falls inside the stated range.
By their numbers in this assay, from the lowest: compound 1; then compounds 3 and 2 (each within the scatter of the next).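

In this assay, the exchange of 1-((dimethylcarbamoyl)methyl)ethyl for phenyl comes to a 1.3-fold lower number from compound 2 to compound 3 (0.12 log units; within the scatter), so at this saturated chain carbon, an amide-bearing group with no ring and an aromatic ring of carbon only give numbers that cannot be told apart. This is the first step shown that isolates a single place, since the earlier pair differed in more than one, and it shows that, in this pair, the number does not depend on keeping the amide group at this position. Nothing at hand explains why these two different groups give numbers within the scatter of each other.

Compound 2 and compound 3 each differ from compound 1 in more than one place, so the shown steps cannot tie the lower number of compound 1 (1 nM) to any one of its features. As far as these compounds go, it also remains open how the number at this chain carbon would respond to a group of another kind, such as an amine, a carboxylic acid or a cyclohexyl ring, or to a longer chain carrying the phenyl.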